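The source may hold more compounds than are shown below. What is called first, only, known or untested is meant among the compounds shown, and "the series" means these compounds.

Measured in a functional assay on PC-3 cells (Homo sapiens), read by MTT assay, with a stated time of 48 h; on this read-out higher numbers stand for weaker inhibition and lower numbers for stronger inhibition:
compound 1, `CCn1c(C(=O)NCCN(C)C)ccc1C(CC)(CC)c1ccc(OCC(=O)C(C)(C)C)c(C)c1`: 2300 nM
compound 2, `C#CCNC(=O)c1ccc(C(CC)(CC)c2ccc(OCC(O)C(C)(C)C)c(C)c2)n1CC`: 16200 nM
compound 3, `CCn1c(C(=O)N(C)CC(=O)O)ccc1C(CC)(CC)c1ccc(OCC(=O)C(C)(C)C)c(C)c1`: 18400 nM

Compound 2 stands second highest of the three numbers. Its value and that of compound 3 lie within the scatter of each other, while compound 1 sits well below both. Within the data shown here, the only single-point step in the set is an 8.0-fold higher number from compound 1 to compound 3 (0.90 log units; beyond the scatter), an exchange of one group for another on the carbonyl carbon of the shared core.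

Compound 4 is `CCn1c(C(=O)OCc2ccc(F)cc2)ccc1C(CC)(CC)c1ccc(OCC(O)C(C)(C)C)c(C)c1`. It differs from compound 2 by (4-fluorobenzyl)oxy in place of propargylamino on a carbonyl carbon. The change again falls on the carbonyl carbon, so the step from compound 1 to compound 3 is the sole measured point of reference; it shows that exchanges at this carbonyl carbon can shift the number by a modest amount. Among the measured compounds shown here, no measured pair replaces an amino group with an oxy group on that carbonyl, so the direction cannot be read from the data. The expected step is a 1.4-fold lower number from compound 2 to compound 4 (0.13 log units; within the scatter), with the range kept wide. Compound 4 is estimated at 12000 nM, between 3000 nM and 45000 nM.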

Compound 4, half-maximal inhibitory concentration: > 50000 nM
Compound 4: a limit, no number (the forecaster's own chance of this, stated with the estimate: 10%); middle value at least 4.1-fold (0.61 log units) away from the limit.
By their numbers in this assay, from the lowest: compound 1; then compounds 2 and 3 (each within the scatter of the next). At a limit, above all of these: compound 4.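

In this assay compound 4 gives > 50000 nM, which is a limit of the assay and not a number. The exchange of propargylamino for (4-fluorobenzyl)oxy on the carbonyl carbon gives an at least 3.0-fold higher number from compound 2 to compound 4 (0.48 log units; beyond the scatter), so the true size of this step is bounded on one side only. The earlier step at this carbonyl carbon, an 8.0-fold higher number from compound 1 to compound 3 (0.90 log units; beyond the scatter), linked one amino group to another, whereas this pair shows that an oxy group carrying an aromatic ring at the same place also moves the number upward beyond the scatter.

Which part of the exchange carries the step stays open, as the oxy link and the 4-fluorobenzyl group enter together in this one pair. A benzylamino group or a methoxy group on this carbonyl carbon would tell the two apart.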